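A few compounds are considered here, and "the series" means these few. Any claim that something is new, unique, unknown or untested is made for them only; others in the source may bear on it.

For the measured compounds named here, compound 1 `Cc1ccc(CS(=O)(=O)/C(=C/c2ccc(N(C)C)cc2)C(=O)c2ccc(Cl)cc2)cc1` is the only member of this set with a numerical result: in a functional assay on DU-145 cells (Homo sapiens) for inhibition, read by trypan blue exclusion, with a stated time of 96 h (on this read-out lower numbers stand for stronger inhibition of growth and higher numbers for weaker inhibition of growth), compound 1 gives 50000 nM. Compound 2 `CN(C)c1ccc(/C=C(\C(=O)c2ccc(Cl)cc2)S(=O)(=O)c2ccc(Br)cc2)cc1` reaches only a limit, > 100000 nM. Compound 3 `Cc1ccc(S(=O)(=O)/C(=C/c2ccc(N(C)C)cc2)C(=O)c2ccc(Cl)cc2)cc1` likewise reaches only a limit, > 100000 nM. Both of these sit at the limit of > 100000 nM in this assay, at which 2 of the 3 values shown sit. The steps of an at least 2.0-fold higher number from compound 1 to compound 2 (0.30 log units; that floor lies within the scatter) and an at least 2.0-fold higher number from compound 1 to compound 3 (0.30 log units; that floor lies within the scatter) alter the group on the sulfonyl sulfur, and the step that the two limits leave unreadable from compound 2 to compound 3 cannot be read. Compound 4 `Cc1ccc(CS(=O)(=O)/C(=C/c2ccccc2Br)C(=O)c2ccc(Cl)cc2)cc1` differs from compound 1 at another place altogether: 2-bromophenyl in place of 4-(dimethylamino)phenyl on a double-bonded chain carbon bound to a double-bonded chain carbon. Going by the values given here, no measured step touches this double-bonded chain carbon, so there is no measured guide to the direction or size of the change, and the expectation rests on the value of compound 1 alone. Compound 4 is therefore expected to stay near compound 1, with the expected step of a 1.4-fold higher number from compound 1 to compound 4 (0.15 log units; within the scatter) small and the outcome uncertain. The estimate for compound 4 is 70000 nM, within 20000 nM to 200000 nM, with a real chance that only a limit is recorded.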

Compound 4, concentration for 50% growth inhibition: 25000 nM
Beside the measured number, compound 4's estimate is 2.8-fold (0.45 log units) above it; measured number inside the range.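

For the compounds shown here, this is the first measured change at the double-bonded chain carbon: in this assay, the swap of 4-(dimethylamino)phenyl for 2-bromophenyl gives a 2.0-fold lower number from compound 1 to compound 4 (0.30 log units; within the scatter), so the two compounds cannot be told apart here. The group that leaves carries the only nitrogen at this place and a hydrogen-bond acceptor, while the group that enters has neither, so a numerical result in this assay does not depend on either feature. Compound 4 also gives a number, which keeps it apart from the compounds that reach only a limit: the limit of > 100000 nM in this assay, at which 2 of the 4 values shown sit.

On these data alone, only these two groups have been compared at this place, so it remains open how a plain phenyl, a methoxy group or a carboxylic acid on that ring would read. As far as these compounds go, it is also open whether 2-bromophenyl would give a number alongside 4-methylphenyl or 4-bromophenyl on the sulfonyl sulfur.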